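Series notes: replacing the ethyl group on nitrogen

This account rests on a few compounds, and the source may have more. Where it says the series, first, only, none or still open, it means among the compounds named here.

Values in a functional assay on RKOp27 cells (Homo sapiens) for cytotoxicity, read by MTT assay, with a stated time of 3 days (on this read-out lower numbers stand for stronger inhibition and higher numbers for weaker inhibition), so far:
- compound 1 `N#Cc1c(Nc2ccccc2)nc(SCc2nc3ccccc3[nH]2)nc1-c1ccccc1` gives 4.9 nM
- compound 2 `CCNc1nc(SCc2nc3ccccc3[nH]2)nc(-c2ccccc2)c1C#N` gives 7.35 nM

These two numbers are all that is measured, and compound 2 stands level with compound 1 within the scatter, so neither can be ranked. Next in line is compound 3 `N#Cc1c(NC(N)=S)nc(SCc2nc3ccccc3[nH]2)nc1-c1ccccc1`, which has no value yet. The structural change is a group of 3 heavy atoms (1 carbon, 1 nitrogen, 1 sulfur; no ring) in place of a group of 2 heavy atoms (2 carbon; no ring), on a nitrogen on an aromatic ring and it falls on a nitrogen on an aromatic ring. Going by the values given here, the only measured step at that place is a 1.5-fold higher number from compound 1 to compound 2 (0.18 log units; within the scatter), where ethyl took the place of phenyl. That single step involved a different group, so it is thin support, and the range is kept wide. The expected result in this assay is a 1.2-fold higher number from compound 2 to compound 3 (0.09 log units; within the scatter) and no change beyond the scatter is expected. The estimate for compound 3 is 9 nM (expected range 3 nM to 30 nM).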

Compound 3, half-maximal inhibitory concentration: 2.63 nM
Estimate against measurement, compound 3: 3.4-fold (0.53 log units) above; measured number outside the range, below it.
By their numbers in this assay, from the lowest: compounds 3, 1 and 2 (each within the scatter of the next, the first and the last beyond it).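

In this assay, going by these compounds alone, the first change at this nitrogen on an aromatic ring to pass beyond the scatter is the replacement of ethyl by the group of 3 heavy atoms (1 carbon, 1 nitrogen, 1 sulfur), which carries a hydrogen-bond donor and a hydrogen-bond acceptor: a 2.8-fold lower number from compound 2 to compound 3 (0.45 log units; beyond the scatter). Set against phenyl, the same group gives a 1.9-fold lower number from compound 1 to compound 3 (0.27 log units; within the scatter), so it separates only from ethyl, and it cannot be ranked against phenyl. Nothing at hand accounts for this step.

On these data alone, it remains open whether the step follows from the sulfur or from the nitrogen of the entering group. As far as these compounds go, how an unsubstituted amine, an acetyl group or a longer chain would compare at this nitrogen is also open.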